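The source may hold more compounds than are shown below. What is called first, only, known or untested is meant among the compounds shown, and "the series" means these compounds.

Compound 1, `Cn1c(COc2cccc(C(=O)O)c2)nc2cnc(Oc3ccc4c(c3)CCC4)cc21`, in an ADME assay for permeability, using PAMPA, with a stated time of 4 h (on this read-out higher numbers stand for higher permeability and lower numbers for lower permeability), gives 16.5 10^-6 cm/s.
Compound 2, `Cn1c(COc2cccc(C(=O)O)c2)nc2ccc(Oc3ccccn3)cc21`, in this assay gives 2.2 10^-6 cm/s.
Compound 3, `Cn1c(COc2cccc(C(=O)O)c2)nc2ccc(Oc3cc(Cl)ccn3)cc21`, in this assay gives 10.3 10^-6 cm/s.

Among these three numbers compound 3 stands beyond the scatter above compound 2 and within the scatter of compound 1. The step to compound 4, `Cc1ccnc(Oc2ccc3nc(COc4cccc(C(=O)O)c4)n(C)c3c2)c1`, is methyl in place of chloro on an aromatic carbon. Within the data shown here, the one measured step that bears on this place is a 4.7-fold higher number from compound 2 to compound 3 (0.67 log units; beyond the scatter), a modest rise beyond the scatter, which shows that a change at this aromatic carbon can move the read-out. No measured pair exchanges chloro for methyl, so the direction of the present step is not shown directly by any pair. Among the measured compounds shown here, since compound 3 gives 10.3 10^-6 cm/s and the only known step at this place was modest, compound 4 is expected to remain near that number, with at most a small fall. The change is expected to be small: a 1.4-fold lower number from compound 3 to compound 4 (0.14 log units; within the scatter). The estimate for compound 4 in this assay is 7.5 10^-6 cm/s, with a range from 3.5 10^-6 cm/s to 15 10^-6 cm/s.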

Compound 4, apparent permeability: 3.5 10^-6 cm/s
Estimate against measurement, compound 4: 2.1-fold (0.33 log units) above; measured number inside the range.
By their numbers in this assay, from the lowest: compounds 2 and 4 (each within the scatter of the next); then compounds 3 and 1 (each within the scatter of the next).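

In this assay, methyl in place of chloro on the aromatic carbon opposite the ring nitrogen gives a 2.9-fold lower number from compound 3 to compound 4 (0.47 log units; beyond the scatter), so the read-out separates these two groups at this place. Methyl in place of hydrogen on the same carbon gives a 1.6-fold higher number from compound 2 to compound 4 (0.20 log units; within the scatter), which shows that the earlier rise seen with chloro does not extend to every group put there: of the three groups shown at this carbon, chloro alone stands apart from the other two. Nothing at hand explains this difference between chloro and methyl.

Going by these compounds, it remains open whether other groups on this carbon, such as methoxy, fluoro or an amine, would stay with hydrogen and methyl or rise as chloro does. On these data alone, it is also open whether the same exchange of chloro for methyl would give a similar step on a different core.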